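Cytotoxicity notes: nitro for bromo on the shared core

A few compounds are considered here, and "the series" means these few. Any claim that something is new, unique, unknown or untested is made for them only; others in the source may bear on it.

compound 1 `Cc1ccc2[nH]c(=O)c(-c3nc4cc([N+](=O)[O-])ccc4[nH]3)cc2c1` — > 100000 nM
compound 2 `O=c1[nH]c2ccccc2cc1-c1nc2cc(F)ccc2[nH]1` — > 100000 nM
compound 3 `O=c1[nH]c2ccccc2cc1-c1nc2cc(Br)ccc2[nH]1` — > 100000 nM

In an ADME assay on L02 cells (Homo sapiens) for cytotoxicity, read by MTT assay, with a stated time of 48 h (a lower number here means a stronger inhibitor, a higher number a weaker inhibitor), compound 1 gives > 100000 nM, which is a limit of the assay and not a number. Compound 2 gives > 100000 nM, also a limit. Compound 3 gives > 100000 nM, again a limit. Among the measured compounds shown here, the single measured step, a step that the two limits leave unreadable from compound 2 to compound 3, is unreadable because both of its ends sit at the limit (the limit of > 100000 nM in this assay, at which 3 of the 3 values shown sit). Compound 3 therefore stands where every compound of the series stands so far: at the limit, with no number to rank it against the other two.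

Compound 4 `O=c1[nH]c2ccccc2cc1-c1nc2cc([N+](=O)[O-])ccc2[nH]1` is not yet measured. It differs from compound 3 by nitro in place of bromo on an aromatic carbon. The measured step bears on the same aromatic carbon, but its size is not known, so it gives no direction. Compound 1, which also carries a nitro group, sits at the limit as well. On that basis compound 4 is expected to stay at the limit, with a step that the limit leaves unreadable from compound 3 to compound 4 estimated as none beyond the scatter. For compound 4 the estimate is 150000 nM, with a range from 50000 nM to 500000 nM, and most likely only a limit will be reported.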

Compound 4, half-maximal inhibitory concentration: > 100000 nM
Compound 4: a limit, no number (the forecaster's own chance of this, stated with the estimate: 85%); the middle value lies beyond the limit too.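

In this assay compound 4 gives > 100000 nM as a limit and not a number. No new step can be read among compound 1, compound 2, compound 3 and compound 4, because both ends of every step sit at the limit: the limit of > 100000 nM in this assay, at which 4 of the 4 values shown sit. How far any of these compounds lies beyond that limit remains open.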